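A few compounds are considered here, and "the series" means these few. Any claim that something is new, unique, unknown or untested is made for them only; others in the source may bear on it.

Measured in an ADME assay (liver) for metabolic stability, with Liver microsome (Homo sapiens) as the target, read by LC-MS, using microsomes, tested at 0.1 uM; on this read-out higher numbers stand for fast clearance and lower numbers for slow clearance:

Compound 1 `CNc1nc(NCCCN(C)C)c2sc(-c3ccc(C(F)(F)F)cc3)cc2n1` gives 14 mL.min-1.g-1
Compound 2 `CN(C)CCCNc1nc(N)nc2cc(-c3ccc(C(F)(F)F)cc3)sc12` gives 16.9 mL.min-1.g-1

Compound 2, at 16.9 mL.min-1.g-1, stands level with compound 1 within the scatter, and only these two compounds have been measured. The next structure is compound 3 `COc1nc(NCCCN(C)C)c2sc(-c3ccc(C(F)(F)F)cc3)cc2n1`, which keeps the shared core and the (3-(dimethylamino)propyl)amino group of compound 2. It differs from compound 2 at one place: methoxy in place of amino on an aromatic carbon. Methoxy stands in place of amino on an aromatic carbon, between two ring nitrogen atoms.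

Within the data shown here, one measured step bears on this place: a 1.2-fold higher number from compound 1 to compound 2 (0.08 log units; within the scatter). That step, hydrogen in place of methyl on a nitrogen on an aromatic ring, stayed within the scatter. Among the measured compounds shown here, it still keeps a nitrogen on that carbon, however, and no measured compound carries methoxy, so the data give no direct size for this exchange. In this assay, no step beyond the scatter is therefore expected, with only a slight lean towards a higher number and a wide allowance on either side. The expected change is a 1.2-fold higher number from compound 2 to compound 3 (0.07 log units; within the scatter). For compound 3 the estimate is 20 mL.min-1.g-1, with an expected range from 9 mL.min-1.g-1 to 45 mL.min-1.g-1.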

Compound 3, intrinsic clearance in microsomes: < 17 mL.min-1.g-1
Compound 3: no number, only a limit (the forecaster's own chance of this, stated with the estimate: 3%); middle value at least 1.1-fold (0.07 log units) from the limit.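

In this assay compound 3 gives < 17 mL.min-1.g-1 as a limit and not a number, so the steps to compound 3 from compound 1 and from compound 2 cannot be read: the limit of < 17 mL.min-1.g-1 in this assay, at which 1 of the 3 values shown sits. The compounds shown leave open how large the change from amino to methoxy on this aromatic carbon is, and in which direction it runs.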